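Removing a chloro group from compound 3

The source may hold more compounds than are shown below. What is called first, only, known or untested is meant among the compounds shown, and "the series" means these compounds.

In a functional assay on U-251 cells (Homo sapiens) for inhibition, read by MTT assay, with a stated time of 48 h (on this read-out higher numbers stand for weaker inhibition and lower numbers for stronger inhibition), three compounds have been measured so far. Compound 1 `C#CCN(C)CCCOc1cc(NC(=O)CCCCCCCCC(=O)NO)ccc1Cl` gives 33200 nM, compound 2 `C#CCN(C)CCCOc1cc(NC(=O)CCCCCCCC(=O)NO)ccc1Cl` gives 11500 nM and compound 3 `C#CCN(C)CCCOc1cc(NC(=O)CCCCCCC(=O)NO)c(Cl)cc1Cl` gives 50600 nM. Compound 3 thus sits at the weak end of the set, within the scatter of compound 1, while compound 2 lies beyond the scatter on the stronger side of compound 3.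

Next is compound 4 `C#CCN(C)CCCOc1cc(NC(=O)CCCCCCC(=O)NO)ccc1Cl`, which differs from compound 3 by one change: hydrogen in place of chloro on an aromatic carbon. Within the data shown here, no measured pair tests this change directly. Among the measured compounds shown here, the only measured step, a 2.9-fold lower number from compound 1 to compound 2 (0.46 log units; beyond the scatter), is a modest one that shortens the chain, and it suggests that chain length matters. Compound 4 keeps the chain of compound 3 and takes on the chloro pattern of compound 2, which gives 11500 nM. Compound 1 shares that pattern yet gives 33200 nM, so the pattern alone does not secure a low number.

A modest drop beyond the scatter is expected, with wide uncertainty. The expected change is a 3.2-fold lower number from compound 3 to compound 4 (0.50 log units; beyond the scatter), as an estimate. For compound 4 the estimated value is 16000 nM, with an expected range of 5000 nM to 45000 nM.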

Compound 4, half-maximal inhibitory concentration: 120 nM
Compound 4: the middle estimate sits 130-fold (2.12 log units) above what was measured, outside the stated range (below it).
By their numbers in this assay, from the lowest: compound 4; then compound 2; then compounds 1 and 3 (each within the scatter of the next).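

In this assay, the chloro group on the aromatic carbon para to the 3-(methyl(propargyl)amino)propoxy group proves decisive at this chain length, with hydrogen in its place giving a 420-fold lower number from compound 3 to compound 4 (2.62 log units; beyond the scatter) and moving the series into a far lower range than the other compounds reached. Among these compounds, the chain is also more sensitive than the modest step of a 2.9-fold lower number from compound 1 to compound 2 (0.46 log units; beyond the scatter) indicated, since shortening it further gives a 96-fold lower number from compound 2 to compound 4 (1.98 log units; beyond the scatter) and the full change in chain length gives a 280-fold lower number from compound 1 to compound 4 (2.44 log units; beyond the scatter) among compounds with the same chloro pattern, so the numbers fall with each shortening across compound 1, compound 2 and compound 4, with compound 3 the one shorter-chain compound that goes against this. No measurement at hand accounts for either large step.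

Among the compounds shown here, whether the second chloro group has the same effect on the longer chains of compound 1 and compound 2 remains open, as compound 3 is the only compound carrying it. Also open, from the compounds shown here alone, are a chain shorter than that of compound 4 and a fluoro or methoxy group on the same aromatic carbon.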